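This account rests on a few compounds, and the source may have more. Where it says the series, first, only, none or still open, it means among the compounds named here.

Measured in a functional assay on L1210 cells (Mus musculus) for cytotoxicity; on this read-out higher numbers stand for weaker inhibition and lower numbers for stronger inhibition:
Compound 1 `CCCCCCCCCCCCCC[C@H]1N[C@H](CO)[C@H]1O`: 4.5 ug/mL
Compound 2 `CCCCCCCCCCCCCC[C@@H]1N[C@H](CO)[C@H]1O`: 4.5 ug/mL
Compound 3 `CCCCCCCCCCCCCC[C@H]1N[C@@H](CO)[C@@H]1O`: 1.6 ug/mL

Compound 3 has the lowest number of the three, which makes it the strongest inhibitor so far. Compound 4 `CCCCCCCCCCCCCC[C@H]1N[C@@H](CO)[C@H]1O` keeps the same atoms and bonds as compound 3: the two compounds have the same atoms and bonds and differ only in configuration as drawn: 1 of 3 stereo elements differ; a stereocentre at a saturated ring carbon is drawn R in compound 3 and S in compound 4. Only the drawn configuration at that saturated ring carbon changes, from R in compound 3 to S in compound 4.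

Among the measured compounds shown here, the closest precedent is the one measured step that inverts a single stereocentre, no change at the digits printed from compound 1 to compound 2 (within the scatter). The steps that invert more centres moved the number only modestly: a 2.8-fold lower number from compound 1 to compound 3 (0.45 log units; beyond the scatter) and a 2.8-fold lower number from compound 2 to compound 3 (0.45 log units; beyond the scatter). Stereochemistry therefore shifts this read-out little in these compounds, so only a small step is expected in this assay. Any move is more likely upward, as compound 3 already sits lowest at 1.6 ug/mL. The expected result is a 1.6-fold higher number from compound 3 to compound 4 (0.19 log units; within the scatter), probably within the scatter. For compound 4 the estimate is 2.5 ug/mL, with an expected range from 1.1 ug/mL to 5.5 ug/mL.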

Compound 4, half-maximal inhibitory concentration: > 10 ug/mL
Compound 4 gave a limit, no number; the forecaster's own chance of this, stated with the estimate: 3%; at least 4.0-fold (0.60 log units) between middle value and limit.
By their numbers in this assay, from the lowest: compound 3; then compounds 1 and 2 (each within the scatter of the next). At a limit, above all of these: compound 4.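

In this assay compound 4 gives > 10 ug/mL, which is a limit of the assay and not a number. Inverting a single saturated ring carbon can clearly matter here: the new result shows an at least 6.2-fold higher number from compound 3 to compound 4 (0.79 log units; beyond the scatter) and an at least 2.2-fold higher number from compound 1 to compound 4 (0.34 log units; beyond the scatter), whereas the earlier single inversion showed no change at the digits printed from compound 1 to compound 2 (within the scatter). With two stereocentres inverted there is an at least 2.2-fold higher number from compound 2 to compound 4 (0.34 log units; beyond the scatter), so among these four compounds compound 4 alone sits at a limit, and a small change in configuration is not always a small change in this read-out.

On these data alone, the full size of these steps stays open. Also open, as far as these compounds go, is whether a carboxylic acid or a shorter chain on the shared core would respond to the same inversion in the same way.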